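The source may hold more compounds than are shown below. What is called first, only, known or untested is meant among the compounds shown, and "the series" means these compounds.

Working notes on aryl swaps on the shared core. In a functional assay on A549 cells (Homo sapiens) for antiproliferative activity, read by MTT assay, with a stated time of 72 h (a higher number here means a weaker inhibitor, a lower number a stronger inhibitor), compound 1 `COc1cc(C(=O)c2sc3ccccc3c2-c2ccc(F)cc2)cc(OC)c1OC` gives 3200 nM and compound 2 `COc1cc(C(=O)c2sc3ccccc3c2-c2ccc(C)cc2)cc(OC)c1OC` gives 7800 nM, which is a 2.4-fold higher number from compound 1 to compound 2 (0.39 log units; beyond the scatter). Compound 3 `COc1ccccc1-c1c(C(=O)c2cc(OC)c(OC)c(OC)c2)sc2ccccc12` has no number, only a limit of > 10000 nM. The swap to compound 4 `CCOc1ccc(-c2c(C(=O)c3cc(OC)c(OC)c(OC)c3)sc3ccccc23)cc1` is 4-ethoxyphenyl in place of 2-methoxyphenyl on an aromatic carbon, with 4-ethoxyphenyl in place of 2-methoxyphenyl on an aromatic carbon. The nearest measured steps are the same kind of aryl swap: an at least 3.1-fold higher number from compound 1 to compound 3 (0.49 log units; beyond the scatter), and an at least 1.2-fold higher number from compound 2 to compound 3 (0.10 log units; that floor lies within the scatter), whose floor lies within the scatter. Read in reverse, they point to a modest fall in this assay, with compound 2 at 7800 nM as the closest reference. The expected change is an at least 1.6-fold lower number from compound 3 to compound 4 (0.22 log units; that floor lies within the scatter). The estimate for compound 4 is 6000 nM, within an expected range of 2200 nM to 10000 nM.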

Compound 4, half-maximal inhibitory concentration: 3100 nM
The estimate for compound 4 lay 1.9-fold (0.29 log units) above the measured number; measured number inside the range.
By their numbers in this assay, from the lowest: compounds 4 and 1 (each within the scatter of the next); then compound 2. At a limit, above all of these: compound 3.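

Compound 3 stands only at a limit of the assay: the limit of > 10000 nM in this assay, at which 1 of the 4 values shown sits. In this assay, 4-ethoxyphenyl in place of 2-methoxyphenyl gives an at least 3.2-fold lower number from compound 3 to compound 4 (0.50 log units; beyond the scatter), and ethoxy in place of methyl gives a 2.5-fold lower number from compound 2 to compound 4 (0.40 log units; beyond the scatter). Ethoxy in place of fluoro gives a 1.0-fold lower number from compound 1 to compound 4 (0.01 log units; within the scatter), so the rise seen from fluoro to methyl does not carry on to ethoxy.

The step from 2-methoxyphenyl to 4-ethoxyphenyl changes both the chain and its place on the phenyl ring, and the compounds shown do not separate the two. On these data alone, how an amine or a butoxy chain in place of ethoxy would read remains open.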